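The source may hold more compounds than are shown below. What is called first, only, known or untested is meant among the compounds shown, and "the series" means these compounds.

Going by the values given here, in an ADME assay on SK-OV-3 cells (Homo sapiens) for cytotoxicity, read by sulforhodamine B assay, with a stated time of 48 h, tested at 10 uM (on this read-out lower numbers stand for less inhibition and higher numbers for more inhibition at the one concentration tested (going by the name of the read-out)), compound 2 `COc1nc2ccc(Br)cc2cc1C(c1ccccc1)n1cc(-c2ccccc2C(F)(F)F)nn1` gives 9.55%, the higher of the two numbers measured so far. Among the compounds with values here, the only other measured compound, compound 1 `COc1nc2ccc(Br)cc2cc1C(c1ccccc1)n1cc(-c2ccccc2F)nn1`, gives 7.33% in this assay; the one measured step, a number 2.2 percentage points higher from compound 1 to compound 2 (within the scatter), is within the scatter, so the two compounds cannot be told apart on this read-out, and both sit at the low end of the percentage scale, meaning little inhibition at the single concentration tested.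

Compound 3 `COc1nc2ccc(Br)cc2cc1C(c1ccccc1)n1cc(-c2ccc(F)cc2)nn1` has not yet been measured. It differs from compound 2 by 4-fluorophenyl in place of 2-(trifluoromethyl)phenyl on an aromatic carbon. Within the data shown here, the only step that bears on this change is a number 2.2 percentage points higher from compound 1 to compound 2 (within the scatter), which swapped one substituent on the same phenyl ring for another and produced nothing beyond the scatter. Among the measured compounds shown here, nothing measured so far shows that changing the group on this ring shifts the read-out, so the same is expected here. For compound 3 the expected step is a number 1.6 percentage points lower from compound 2 to compound 3 (within the scatter), nothing beyond the scatter. Compound 3 is therefore estimated to give 8% in this assay, with a range from 0% to 20%.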

Compound 3, a percentage reported as inhibition, at one concentration (the size of the read-out at that concentration, not a potency): 14.3%
Compound 3: the middle estimate sits 6.3 percentage points below what was measured; the measured number falls inside the stated range.
By their numbers in this assay, from the lowest: compounds 1, 2 and 3 (each within the scatter of the next).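

In this assay the group on this aromatic carbon of the five-membered ring now comes in three forms, and the new steps of a number 4.8 percentage points higher from compound 2 to compound 3 (within the scatter) and a number 7 percentage points higher from compound 1 to compound 3 (within the scatter) both stay within the scatter. Going by these compounds alone, the second of these steps is the first comparison in which only the place of the fluorine on the phenyl ring differs, 4-fluorophenyl in place of 2-fluorophenyl, and even this gives no difference that can be told apart from the ordinary variation between repeated measurements, so the three groups cannot be ranked on this read-out. No supporting measurement is available that would help explain these numbers.

From the compounds shown here alone, all three compounds carry a fluorine-bearing phenyl ring at this place, so it remains open whether a different kind of group there, such as an amine, a carboxylic acid or a longer alkyl chain, would shift the read-out beyond the scatter. Going by these compounds, it also remains open whether changes elsewhere on the shared core, such as replacing the methoxy group or the bromine, would do so.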